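From 4-methoxyphenyl to 2-(hydroxymethyl)phenyl: estimating compound 3

This account rests on a few compounds, and the source may have more. Where it says the series, first, only, none or still open, it means among the compounds named here.

For the measured compounds named here, in a functional assay on SK-N-SH cells (Homo sapiens) for inhibition, read by MTT assay, with a stated time of 72 h, tested at 50 uM (a higher number here means more inhibition of growth at the concentration tested, a lower number less inhibition of growth), compound 2 `C=CCc1ccc(OCc2cn(-c3ccc(OC)cc3)nn2)c(O)c1` gives 68.5%, the higher of the two numbers so far. Going by the values given here, the only other measured compound, compound 1 `C=CCc1ccc(OCc2cn(-c3ccccc3Cl)nn2)c(O)c1`, gives 42.8%, a gap beyond the scatter.

The next compound to be measured is compound 3 `C=CCc1ccc(OCc2cn(-c3ccccc3CO)nn2)c(O)c1`. Its difference from compound 2 is 2-(hydroxymethyl)phenyl in place of 4-methoxyphenyl on an aromatic nitrogen. The two have the same atoms, joined differently, and the exchange takes place on an aromatic nitrogen of a five-membered aromatic ring with 3 nitrogen.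

Among the compounds with values here, one measured step bears on this place: a number 25.7 percentage points higher from compound 1 to compound 2 (beyond the scatter), a modest step with 4-methoxyphenyl in place of 2-chlorophenyl. By name, the 2-(hydroxymethyl)phenyl group of compound 3 is closer to the 2-chlorophenyl group of compound 1 than to the 4-methoxyphenyl group. Within the data shown here, no measured compound carries the hydroxymethyl group, however, so only part of that step is expected to be reversed in this assay, and this rests on a single pair.

The expected step is a number 16.5 percentage points lower from compound 2 to compound 3 (beyond the scatter). Compound 3 is estimated at 52%, with an expected range from 32% to 70%.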

Compound 3, percent growth inhibition at one concentration: 87.1%
Compound 3: the middle estimate sits 35.1 percentage points below what was measured, outside the stated range (above it).
By their numbers in this assay, from the lowest: compound 1; then compound 2; then compound 3.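

In this assay, the aryl group on the aromatic nitrogen of the triazole-free wording aside, the shared core tolerates a substituent on the phenyl ring carbon named in 2-chlorophenyl and 2-(hydroxymethyl)phenyl, and the outcome depends on which group stands there: hydroxymethyl in place of chloro gives a number 44.3 percentage points higher from compound 1 to compound 3 (beyond the scatter). The low number of compound 1 therefore does not go with every 2-substituted phenyl group, and the 4-methoxyphenyl group does not mark the top of the series, since the exchange of atoms without a change in heavy-atom count gives a number 18.6 percentage points higher from compound 2 to compound 3 (beyond the scatter), along with a change from 0 hydrogen-bond donors to 1. No measurement on these compounds accounts for the order of the three numbers.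

It remains open whether the hydrogen-bond donor of the hydroxymethyl group or the place of that group on the phenyl ring carries the step, as neither a methyl ether of the hydroxymethyl group nor a 4-(hydroxymethyl)phenyl group is among the compounds shown. An aminomethyl group or a carboxylic acid at this place is also untested in the compounds shown, and a single tested concentration leaves the shape of any concentration response unknown.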